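Configuration changes at the assay limit

This account rests on a few compounds, and the source may have more. Where it says the series, first, only, none or still open, it means among the compounds named here.

In a functional assay on HepG2 cells (Homo sapiens) for cytotoxicity, read by MTT assay, with a stated time of 72 h (a lower number here means a stronger inhibitor, a higher number a weaker inhibitor), compound 1 `C=C(C)[C@@H]1CC[C@](C)(O)[C@H]1/C=C/C(C)=C/[C@@H]1C[C@@]23[C@H](OCCC[C@@H]2/C(=C(/C)C=O)CC[C@]3(C)O)O1` gives > 10000 nM, which is a limit and not a number. Compound 2 `C=C(C)[C@@H]1CC[C@](C)(O)[C@H]1/C=C/C(C)=C/[C@@H]1C[C@@]23[C@H](OCCC[C@@H]2/C(=C(\C)C=O)CC[C@]3(C)O)O1` gives > 10000 nM, also a limit and not a number, so compound 2 has no readable position in the series. Compound 3 `C=C(C)[C@H]1CC[C@@](C)(O)[C@@H]1/C=C/C(C)=C/[C@@H]1C[C@@]23[C@H](OCCC[C@@H]2/C(=C(/C)C=O)CC[C@]3(C)O)O1` departs from it in configuration alone: the two compounds have the same atoms and bonds and differ only in configuration as drawn: 4 of 11 stereo elements differ; a stereocentre at a saturated ring carbon is drawn R in compound 2 and S in compound 3; a stereocentre at a saturated ring carbon is drawn S in compound 2 and R in compound 3; a stereocentre at a saturated ring carbon is drawn S in compound 2 and R in compound 3; a double bond is drawn E in compound 2 and Z in compound 3. The double bond of compound 3 is drawn Z, as in compound 1. Going by the values given here, the only measured step is a step that the two limits leave unreadable from compound 1 to compound 2, so it offers no size to carry over. The evidence is the limit of > 10000 nM in this assay, at which 2 of the 2 values shown sit, together with the fact that compounds 1 and 2 differ only in the configuration as drawn. No clear step in either direction is therefore expected in this assay. The expected change is a step that the limit leaves unreadable from compound 2 to compound 3, and it will probably remain unreadable. Compound 3 is expected at about 20000 nM, with an estimated range of 6000 nM to 60000 nM, most likely reported as a limit again.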

Compound 3, half-maximal inhibitory concentration: > 10000 nM
Compound 3: only a limit was reported; the forecaster's own chance of this, stated with the estimate: 85%; the middle value lies beyond the limit too.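

In this assay, going by these compounds alone, compound 3 gives > 10000 nM, a limit and not a number, so no step among compound 1, compound 2 and compound 3 can be read. From the compounds shown here alone, whether the configuration of the double bond or the stereocentres changes cytotoxicity at all remains open.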